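The source may hold more compounds than are shown below. What is called first, only, known or untested is meant among the compounds shown, and "the series" means these compounds.

The measured compounds and their values:

Compound 1 `CCOC(=O)c1ccc(-c2nn(C)c3ccccc23)cc1`: in a functional assay on cells (Platelet, Homo sapiens) for inhibition (a higher number here means a weaker inhibitor, a lower number a stronger inhibitor), compound 1 gives > 10000 nM, which is a limit of the assay and not a number.
Compound 2 `CCCn1nc(-c2ccc(C(=O)OCC)cc2)c2ccccc21`: in this assay compound 2 gives > 10000 nM, again a limit and not a number.
Compound 3 `COC(=O)c1ccc(-c2nn(Cc3ccccc3)c3ccccc23)cc1`: in this assay compound 3 gives > 10000 nM, also a limit.

Compound 1 and compound 2 differ in one place: ethyl in place of hydrogen on a saturated chain carbon bound to an aromatic nitrogen. The step that the two limits leave unreadable from compound 1 to compound 2 cannot be sized because the limit of > 10000 nM in this assay, at which 3 of the 3 values shown sit, holds both of its values.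

Compound 4 `CCCOC(=O)c1ccc(-c2nn(Cc3ccccc3)c3ccccc23)cc1` has not yet been measured. It differs from compound 3 by ethyl in place of hydrogen on a saturated chain carbon bound to an oxygen next to a carbonyl group. The difference between the core of compound 3 and the core of compound 1 is not broken down here. The change from compound 1 to compound 2 sits on a saturated chain carbon bound to an aromatic nitrogen, whereas the change from compound 3 to compound 4 sits on a saturated chain carbon bound to an oxygen next to a carbonyl group; the two are the same kind of change, not the same change.

The step in this assay is expected to be a step that the limit leaves unreadable from compound 3 to compound 4, which rests on nothing more than the earlier pair, whose step stayed unreadable because the limit of > 10000 nM in this assay, at which 3 of the 3 values shown sit, holds every value shown. Within the data shown here, compound 4 is expected to give 20000 nM because the limit of > 10000 nM in this assay, at which 3 of the 3 values shown sit, holds all three values measured so far.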

Compound 4, half-maximal inhibitory concentration: > 10000 nM
Compound 4 ended at the assay's limit; the forecaster's own chance of this, stated with the estimate: 85%; the middle value is on the limit's open side.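

In this assay compound 4 gives > 10000 nM, which is a limit of the assay and not a number. No step can be read from compound 3 to compound 4, because the two compounds sit at the same limit: the limit of > 10000 nM in this assay, at which 4 of the 4 values shown sit.

The compounds shown leave open how weak each of the four is in this assay, and which change, if any, would give a value readable as a number.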